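The source may report more compounds than this note shows. Statements on the series, on what has been measured and on what is new or still open speak of the compounds shown alone.

In a functional assay on LNCaP cells (Homo sapiens) for cytotoxicity, read by MTT assay, with a stated time of 72 h (a lower number here means a stronger inhibitor, a higher number a weaker inhibitor), compound 2 `CC1=C(/C=C/C(=O)/C=C/c2ccccc2F)C(C)(C)CCC1O` gives 2900 nM, a number level with that of compound 1 `CC1=C(/C=C/C(=O)/C=C/c2ccccc2C(F)(F)F)C(C)(C)CCC1O`, which gives 2900 nM; together these two stand as the highest of the three numbers. Compound 3 `CC1=C(/C=C/C(=O)/C=C/c2cccc(C(F)(F)F)c2F)C(C)(C)CCC1O` gives 1100 nM, the lowest of the set. The move from compound 2 to compound 4 `COc1cccc(/C=C/C(=O)/C=C/C2=C(C)C(O)CCC2(C)C)c1` is 3-methoxyphenyl in place of 2-fluorophenyl on a double-bonded chain carbon bound to a double-bonded chain carbon. Two measured steps alter the same aromatic ring: no change at the digits printed from compound 1 to compound 2 (within the scatter) and a 2.6-fold lower number from compound 2 to compound 3 (0.42 log units; beyond the scatter). Neither replaces the whole substituted phenyl with a methoxy-bearing one, so neither bears directly on this change; they show only that single alterations on this ring have shifted this assay by nothing beyond the scatter or by a modest amount. The step of a 1.2-fold lower number from compound 2 to compound 4 (0.06 log units; within the scatter) is therefore expected to fall within or close to the scatter, with no direction favored. For compound 4 the estimate in this assay is 2500 nM, with a range from 900 nM to 7000 nM.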

Compound 4, half-maximal inhibitory concentration: 4900 nM
Estimate against measurement, compound 4: 2.0-fold (0.29 log units) below; the measured number falls inside the stated range.
By their numbers in this assay, from the lowest: compound 3; then compounds 1, 2 and 4 (each within the scatter of the next).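

In this assay, among these compounds, the earlier steps altered single groups on the ring, whereas this one exchanges the whole 2-fluorophenyl for 3-methoxyphenyl on a double-bonded chain carbon bound to a double-bonded chain carbon (a 1.7-fold higher number from compound 2 to compound 4 (0.23 log units; within the scatter)). A change that takes out fluorine and brings in oxygen, with a hydrogen-bond acceptor counted where none stood, thus stays within the scatter, so compound 2 and compound 4 cannot be ranked at this place. Nothing measured here accounts for this result.

The compounds shown leave open whether the group or its place on the ring matters more, which a 3-fluorophenyl or a 2-methoxyphenyl partner would separate. As far as these compounds go, it also remains open whether an amine, a carboxylic acid or a longer chain on this phenyl would move the number beyond the scatter.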